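A few compounds are considered here, and "the series" means these few. Any claim that something is new, unique, unknown or untested is made for them only; others in the source may bear on it.

Working notes on the series. For the measured compounds named here, in a functional assay on HUVEC cells (Homo sapiens) for antiproliferative activity, read by MTT assay, with a stated time of 48 h (on this read-out lower numbers stand for stronger inhibition and higher numbers for weaker inhibition), compound 1 (`CCN(CC)CC(=O)Nc1ccc(Nc2cc(Cl)nc(-c3ccc(OC)cc3)n2)cc1`) gives 15000 nM as the higher of the two numbers so far. Compound 2 (`COc1ccc(-c2nc(Cl)cc(Nc3ccc(NC(=O)CN4CCCC4)cc3)n2)cc1`) gives 4820 nM with pyrrolidin-1-yl in place of diethylamino. Going by the values given here, that is the only measured step (a 3.1-fold lower number from compound 1 to compound 2 (0.49 log units; beyond the scatter)), and it lies on the chain, away from the carbon changed next. Compound 3 (`CCN(CC)CC(=O)Nc1ccc(Nc2nc(-c3ccc(OC)cc3)nc(Cl)c2-c2ccccc2)cc1`) carries, on the core of compound 1, the change phenyl in place of hydrogen on an aromatic carbon on an aromatic carbon ortho to a chloro group. Among the compounds with values here, no measured step covers a change at this carbon, so the step to compound 2 serves only as a rough guide to size, and the direction is uncertain. In this assay a modest step towards a lower number is expected (a 2.5-fold lower number from compound 1 to compound 3 (0.40 log units; beyond the scatter)) with a wide margin. Compound 3 is expected at 6000 nM (estimated range 1500 nM to 20000 nM).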

Compound 3, half-maximal inhibitory concentration: > 40000 nM
Compound 3 gave a limit, no number (the forecaster's own chance of this, stated with the estimate: 15%); middle value at least 6.6-fold (0.82 log units) away from the limit.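

Compound 3 is a limit of the assay and not a number: the limit of > 40000 nM in this assay, at which 1 of the 3 values shown sits.

In this assay, phenyl in place of hydrogen on this aromatic carbon, ortho to a chloro group, gives an at least 2.6-fold higher number from compound 1 to compound 3 (0.42 log units; beyond the scatter), so a change at this carbon can shift the series towards weaker inhibition. The step on the chain (a 3.1-fold lower number from compound 1 to compound 2 (0.49 log units; beyond the scatter)) runs the other way, which shows that the chain step gives no guide to direction at this carbon.

Still open, as far as these compounds go, is whether a methyl group or an amine on this carbon would keep the number of compound 1 or move it in either direction. Also open, from the compounds shown here alone, is whether phenyl at this carbon has the same outcome with the pyrrolidin-1-yl chain of compound 2.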